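Swapping a benzothiazole for an acetylpyrrolidine in a REV-ERB agonist

A few compounds are considered here, and "the series" means these few. Any claim that something is new, unique, unknown or untested is made for them only; others in the source may bear on it.

Measured compounds:
- compound 1, `CC(C)(C)OC(=O)CN(Cc1ccc(Cl)cc1)Cc1nc2ccccc2s1`, "not determined" (no result reported)
- compound 2, `O=[N+]([O-])c1ccc(CN(Cc2ccc(Cl)cc2)Cc2nc3ccccc3s2)s1`, 4000 nM

Among the measured compounds shown here, compound 2, `O=[N+]([O-])c1ccc(CN(Cc2ccc(Cl)cc2)Cc2nc3ccccc3s2)s1`, is the only compound of this small set with a number: in a functional assay on HEK293 cells for agonist activity at nuclear receptor subfamily 1 group D member 1 (Homo sapiens), read by a luciferase reporter, with a stated time of 24 h (a higher number here means that more compound is needed for the effect, a lower number that less compound is needed), compound 2 gives 4000 nM. For the measured compounds named here, compound 1, `CC(C)(C)OC(=O)CN(Cc1ccc(Cl)cc1)Cc1nc2ccccc2s1`, shares much of the same shape, but in this assay compound 1 is recorded as "not determined" (no result reported), so there is nothing to set against compound 2 and no step between measured compounds to learn from.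

Compound 3, `CC(=O)N1CCC(CN(Cc2ccc(Cl)cc2)Cc2ccc([N+](=O)[O-])s2)C1`, is the next question. It differs from compound 2 in one place: 1-acetylpyrrolidin-3-yl in place of 1,3-benzothiazol-2-yl on a saturated chain carbon bound to an amine nitrogen. The aromatic two-ring piece leaves and a small, non-aromatic ring carrying an acetyl group enters.

Going by the values given here, with no measured step to lean on, any expectation rests only on the size of this change. Because compound 2 gives 4000 nM and the replacement alters a large part of the molecule, a modest weakening is expected, the step from compound 2 to compound 3 estimated at a 2.0-fold higher number from compound 2 to compound 3 (0.30 log units; within the scatter). Compound 3 is therefore expected to give about 8000 nM, within a range of 2000 nM to 40000 nM.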

Compound 3, half-maximal effective concentration: 1600 nM
Compound 3: middle estimate off by 5.0-fold (0.70 log units), on the high side; measured number below the stated range.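

In this assay, among the compounds shown here, the change gives a 2.5-fold lower number from compound 2 to compound 3 (0.40 log units; beyond the scatter), the first readable step. It shows that, on a saturated chain carbon bound to an amine nitrogen, activity does not depend on the 1,3-benzothiazol-2-yl group, since a 1-acetylpyrrolidin-3-yl group with no aromatic ring is tolerated and even gives a modestly lower number, though this rests on a single pair of compounds. No accompanying measurement explains why the number moved in this direction.

The step replaces the whole group at once, so it cannot separate what the acetyl group contributes from what the non-aromatic ring contributes. A plain pyrrolidine without the acetyl group would begin to pull those two parts apart, while a piperidine ring carrying the same acetyl group would test whether the size of the ring matters at this position.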